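Swapping the aryl amine in a quinazoline thioether series

This account rests on a few compounds, and the source may have more. Where it says the series, first, only, none or still open, it means among the compounds named here.

Measured compounds:
- compound 1 `COc1ccccc1Nc1nc(SCc2ccc(C(F)(F)F)cc2)nc2ccccc12`: 14100 nM
- compound 2 `O=[N+]([O-])c1cccc(Nc2nc(SCc3ccc(C(F)(F)F)cc3)nc3ccccc23)c1`: 13500 nM
- compound 3 `FC(F)(F)c1ccc(CSc2nc(Nc3ccc(C(F)(F)F)cc3)c3ccccc3n2)cc1`: 7880 nM

In a functional assay on PC-3 cells (Homo sapiens) for cytotoxicity, read by MTT assay, with a stated time of 72 h (a higher number here means a weaker inhibitor, a lower number a stronger inhibitor), the three compounds differ only in the aryl group on the nitrogen attached to the shared core. Compound 3 gives 7880 nM, and its distance from the other two, a 1.8-fold lower number from compound 1 to compound 3 (0.25 log units; within the scatter) and a 1.7-fold lower number from compound 2 to compound 3 (0.23 log units; within the scatter), stays within the scatter, as does a 1.0-fold lower number from compound 1 to compound 2 (0.02 log units; within the scatter). On the numbers shown the three compounds cannot be told apart in this assay.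

Compound 4 `COc1cc(Nc2nc(SCc3ccc(C(F)(F)F)cc3)nc3ccccc23)cc(OC)c1` continues the same kind of exchange: 3,5-dimethoxyphenyl in place of 4-(trifluoromethyl)phenyl on a nitrogen on an aromatic ring. The two steps that bear on it, from compound 1 and from compound 2 to compound 3, both changed the same aryl group and both stayed within the scatter, so there is no sign so far that this position moves the read-out. Within the data shown here, the new group differs from the earlier three in carrying two methoxy substituents, which none of the measured aryl groups had, so an effect beyond what has been seen cannot be ruled out, but nothing in the data predicts it.

Compound 4 is therefore expected to give about 11000 nM in this assay, somewhere between 4500 nM and 30000 nM, a step of a 1.4-fold higher number from compound 3 to compound 4 (0.14 log units; within the scatter) that is expected to stay within the scatter.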

Compound 4, half-maximal inhibitory concentration: > 50000 nM
Compound 4: a limit, no number (the forecaster's own chance of this, stated with the estimate: 10%); middle value at least 4.5-fold (0.65 log units) away from the limit.
By their numbers in this assay, from the lowest: compounds 3, 2 and 1 (each within the scatter of the next). At a limit, above all of these: compound 4.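

Compound 4 stands at a limit of the assay, not at a number: the limit of > 50000 nM in this assay, at which 1 of the 4 values shown sits. Even with that limit, this assay now shows that the aryl group on this nitrogen can move the read-out, which compounds 1, 2 and 3 could not show: the change to 3,5-dimethoxyphenyl gives an at least 6.3-fold higher number from compound 3 to compound 4 (0.80 log units; beyond the scatter), while the same group gives an at least 3.7-fold higher number from compound 2 to compound 4 (0.56 log units; beyond the scatter) and an at least 3.5-fold higher number from compound 1 to compound 4 (0.54 log units; beyond the scatter). All three steps lie beyond the scatter, and the exchange with 4-(trifluoromethyl)phenyl keeps 10 heavy atoms on each side while going from 0 hydrogen-bond acceptors to 2 hydrogen-bond acceptors, although the data do not tie the step to that difference.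

The compounds shown do not tell which feature of 3,5-dimethoxyphenyl goes with the step, and the 2-methoxyphenyl of compound 1 shows only that a methoxy group on the aryl ring does not always give it. Going by these compounds, a phenyl ring carrying an amine or a carboxylic acid at this nitrogen would test other kinds of group, and how such groups would read here remains open.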